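Triazole substituent swap: benzyl to butyl on the shared core

The source may report more compounds than this note shows. Statements on the series, on what has been measured and on what is new or still open speak of the compounds shown alone.

Measured so far:
compound 1 `CNc1nc(-c2cn(Cc3cccc(OC)c3)nn2)nc2c1ncn2[C@@H]1O[C@H](CO)[C@@H](O)[C@H]1O` gives 86.1 nM
compound 2 `CCNC(=O)[C@H]1O[C@@H](n2cnc3c(NC)nc(-n4cc(Cc5ccccc5)nn4)nc32)[C@H](O)[C@@H]1O` gives 2.8 nM

In an assay on CHO cells for displacement of a labelled ligand from adenosine receptor A3 (Homo sapiens) (a lower number here means a stronger inhibitor, a higher number a weaker inhibitor), compound 2 stands lowest of the two numbers; compound 1 sits far higher, beyond the scatter. Compound 3 `CCCCc1cn(-c2nc(NC)c3ncn([C@@H]4O[C@H](C(=O)NCC)[C@@H](O)[C@H]4O)c3n2)nn1` is not yet measured. It differs from compound 2 by propyl in place of phenyl on a saturated chain carbon bound to an aromatic carbon. Among the measured compounds shown here, no measured pair shows this change, so its size is unknown from the data. The expectation for compound 3 is a step of a 2.9-fold higher number from compound 2 to compound 3 (0.46 log units; beyond the scatter), a modest rise in the number, though a result within the scatter would not surprise. Compound 3 is expected at 8 nM, in the range 2 nM to 40 nM.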

Compound 3, inhibition constant: 5.6 nM
The estimate for compound 3 lay 1.4-fold (0.15 log units) above the measured number; the measured number falls inside the stated range.
By their numbers in this assay, from the lowest: compounds 2 and 3 (each within the scatter of the next); then compound 1.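

In this assay, propyl in place of phenyl on a saturated chain carbon bound to an aromatic carbon gives a 2.0-fold higher number from compound 2 to compound 3 (0.30 log units; within the scatter). For this pair, then, losing the six-membered aromatic ring does not move the number beyond the scatter, and a plain chain serves as well as benzyl. No available evidence accounts for this result.

From the compounds shown here alone, whether a longer chain, an amine or a carboxylic acid in place of propyl would keep the number in this range remains open. Compound 1 differs from these compounds in more than one place, so it cannot settle this.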